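From 2,6-dichlorophenyl to 2-methoxyphenyl on the carbonyl

The compounds below may be only part of what the source reports. "The series", "measured", "known", "first", "only" and "open" are said of these compounds alone.

Values measured in a functional assay on HeLa cells (Homo sapiens) for inhibition, read by CCK-8 assay, with a stated time of 72 h (a higher number here means a weaker inhibitor, a lower number a stronger inhibitor), are as follows
- compound 1 `Nc1ccccc1NC(=O)c1ccc(CNC(=O)c2n[nH]cc2NC(=O)c2c(F)cccc2Cl)cc1` gives 3270 nM
- compound 2 `Nc1ccccc1NC(=O)c1ccc(CNC(=O)c2n[nH]cc2NC(=O)c2ccccc2)cc1` gives 4060 nM
- compound 3 `Nc1ccccc1NC(=O)c1ccc(CNC(=O)c2n[nH]cc2NC(=O)c2c(Cl)cccc2Cl)cc1` gives 1830 nM

Compound 3 stands apart from only one of the other two: the data show a 1.8-fold lower number from compound 1 to compound 3 (0.25 log units; within the scatter) and also a 2.2-fold lower number from compound 2 to compound 3 (0.35 log units; beyond the scatter). Compound 4 `COc1ccccc1C(=O)Nc1c[nH]nc1C(=O)NCc1ccc(C(=O)Nc2ccccc2N)cc1` has 2-methoxyphenyl in place of 2,6-dichlorophenyl on a carbonyl carbon. Among the measured compounds shown here, no measured step introduces this group. The closest guides are the changes of the same group, which include a 1.2-fold higher number from compound 1 to compound 2 (0.09 log units; within the scatter) and remain small. In this assay a small change is therefore expected, and the estimate is a 1.6-fold higher number from compound 3 to compound 4 (0.21 log units; within the scatter). Compound 4 is expected at 3000 nM, within an estimated range of 1400 nM to 6500 nM.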

Compound 4, half-maximal inhibitory concentration: 8130 nM
Compound 4: the middle estimate sits 2.7-fold (0.43 log units) below what was measured, outside the stated range (above it).
By their numbers in this assay, from the lowest: compounds 3, 1, 2 and 4 (each within the scatter of the next, the first and the last beyond it).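

In this assay, the group on this carbonyl carbon matters more than the halogen exchange between compound 1 and compound 3 suggested: 2-methoxyphenyl gives a 4.4-fold higher number from compound 3 to compound 4 (0.65 log units; beyond the scatter) and a 2.5-fold higher number from compound 1 to compound 4 (0.40 log units; beyond the scatter) in the same series. Against the unsubstituted phenyl, the added methoxy gives a 2.0-fold higher number from compound 2 to compound 4 (0.30 log units; within the scatter) and so does not clearly separate the two compounds. No available evidence bears on the reason for these steps.

The compounds shown leave open whether a hydroxyl or an amine in place of the methoxy would give numbers closer to compound 2 or to compound 3.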